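This account rests on a few compounds, and the source may have more. Where it says the series, first, only, none or still open, it means among the compounds named here.

Compound 1 `CC(C(=O)c1cc(C(F)(F)F)nn1-c1ccc2onc(N)c2c1)c1ccc(-c2ccccc2S(C)(=O)=O)cc1F`: in an assay on isolated protein for inhibition of Trypsin (Homo sapiens) (a higher number here means a weaker inhibitor, a lower number a stronger inhibitor), compound 1 gives > 20000 nM, which is a limit of the assay. Compound 3 `CC(C(=O)c1cc(C(F)(F)F)nn1-c1ccc2onc(N)c2c1)c1ccc(-c2ccccc2S(C)(=O)=O)cc1`: in this assay compound 3 gives > 20000 nM, again a limit. Compound 2 `COc1ccc(-n2nc(C(F)(F)F)cc2C(=O)Cc2ccc(-c3ccccc3S(N)(=O)=O)cc2)cc1`: in this assay compound 2 gives > 2500 nM, also a limit.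

From compound 3 to compound 1 the change is fluoro in place of hydrogen on an aromatic carbon, and the step that the two limits leave unreadable from compound 3 to compound 1. Compound 4 `COc1ccc(-n2nc(C(F)(F)F)cc2C(=O)Cc2ccc(-c3ccccc3S(N)(=O)=O)cc2F)cc1` has not yet been measured; it differs from compound 2 by fluoro in place of hydrogen on an aromatic carbon, the same kind of change, though here the place is meta to a 2-sulfamoylphenyl group rather than meta to a 2-(methylsulfonyl)phenyl group. How the cores of compound 2 and compound 3 differ is not broken down here.

For compound 4 the step that the limit leaves unreadable from compound 2 to compound 4 is expected to be small, resting on compound 2 sitting at the limit of > 2500 nM in this assay, at which 1 of the 3 values shown sits, and on a step that the two limits leave unreadable from compound 3 to compound 1. Compound 4 is estimated at 20000 nM, between 3000 nM and 100000 nM, most likely reported only as a limit.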

Compound 4, inhibition constant: > 6000 nM
Compound 4: no number, only a limit; the forecaster's own chance of this, stated with the estimate: 85%; the middle value lies beyond the limit too.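

Compound 2 and compound 4 are both known only as limits in this assay, so no step can be read between them. The compounds shown leave open whether fluoro in place of hydrogen changes inhibition at all.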